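Swapping the Thiophene Attachment Point in a Small Set

The source may report more compounds than this note shows. Statements on the series, on what has been measured and on what is new or still open speak of the compounds shown alone.

Compound 1 `Clc1ccc(-c2cc(-c3ccsc3)nc(-c3ccccc3Cl)c2)o1`: 0%
Compound 2 `Clc1ccc(-c2cc(-c3cccs3)nc(-c3ccccc3Cl)c2)o1`: 41.3%
Compound 3 `Cc1ccc(-c2cc(-c3ccc(Cl)o3)cc(-c3cccs3)n2)cc1`: 41.8%

These three were tested in an assay on isolated protein for inhibition of DNA topoisomerase 1 (Homo sapiens), tested at 100 uM; a higher number here means a stronger effect of the compound at the concentration tested, a lower number a weaker effect. Compound 2 and compound 3 both carry a thiophen-2-yl group and differ by 4-methylphenyl in place of 2-chlorophenyl on an aromatic carbon; their values lie within the scatter of each other, a number 0.5 percentage points higher from compound 2 to compound 3 (within the scatter). Compound 1 differs from compound 2 by thiophen-3-yl in place of thiophen-2-yl on an aromatic carbon, and this single change made a large step, a number 41.3 percentage points lower from compound 2 to compound 1 (beyond the scatter). Compound 4 `Cc1ccc(-c2cc(-c3ccc(Cl)o3)cc(-c3ccsc3)n2)cc1` has not yet been measured. It arises from compound 3 by thiophen-3-yl in place of thiophen-2-yl on an aromatic carbon, the same kind of change as from compound 2 to compound 1; around the place, a 4-methylphenyl group stands where compound 2 carries a 2-chlorophenyl group. Because a number 41.3 percentage points lower from compound 2 to compound 1 (beyond the scatter) was large, and the two cores gave alike values, for compound 4 the expected step is a number 38.8 percentage points lower from compound 3 to compound 4 (beyond the scatter), resting on that one earlier example. Compound 4 is therefore estimated at 3%, between 0% and 25%.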

Compound 4, a percentage reported as inhibition, at one concentration (the size of the read-out at that concentration, not a potency): 2.6%
Beside the measured number, compound 4's estimate is 0.4 percentage points above it; the measured number falls inside the stated range.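

Moving the attachment from thiophen-2-yl to thiophen-3-yl again removed most of the read-out in this assay, a number 39.2 percentage points lower from compound 3 to compound 4 (beyond the scatter), so the change carried over from one core to the other: the same change on two cores in this assay, a number 41.3 percentage points lower (beyond the scatter) from compound 2 to compound 1 and a number 39.2 percentage points lower (beyond the scatter) from compound 3 to compound 4, 2.1 percentage points apart, within the scatter of two such steps

Exchanging 2-chlorophenyl for 4-methylphenyl stayed small with either thiophene, a number 2.6 percentage points higher from compound 1 to compound 4 (within the scatter): the same change on two cores in this assay, a number 0.5 percentage points higher (within the scatter) from compound 2 to compound 3 and a number 2.6 percentage points higher (within the scatter) from compound 1 to compound 4, 2.1 percentage points apart, within the scatter of two such steps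

For the compounds shown here, this rests on only two pairs of compounds at a single concentration, so it shows no potency and does not establish that the thiophene change would behave alike on any other core.

The compounds shown leave open what an amine or a carboxylic acid would do in place of the methyl group of the 4-methylphenyl ring. They also leave open whether the 5-chlorofuran-2-yl group matters to the thiophene effect.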